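The source may hold more compounds than are shown below. What is called first, only, known or untested is meant among the compounds shown, and "the series" means these compounds.

In a functional assay on HEY cells (Homo sapiens) for cytotoxicity, read by MTT assay, with a stated time of 72 h; on this read-out higher numbers stand for weaker inhibition and lower numbers for stronger inhibition:
compound 1 `COc1cccc(CNC(=O)c2nc(Br)c3cccnc3c2N[C@H]2CC[C@H](N)CC2)c1`: 7000 nM
compound 2 `N[C@H]1CC[C@H](Nc2c(C(=O)NCc3ccccn3)nc(Br)c3cccnc23)CC1`: > 20000 nM (a limit)
compound 3 `N[C@H]1CC[C@H](Nc2c(C(=O)NCc3cccs3)nc(Br)c3cccnc23)CC1`: 11000 nM

Compound 3 sits level with compound 1 within the scatter, as the step of a 1.6-fold higher number from compound 1 to compound 3 (0.20 log units; within the scatter) shows. Compound 2 reports > 20000 nM, which is a limit and not a number.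

Compound 4 `N[C@H]1CC[C@H](Nc2c(C(=O)NCc3ccccc3)nc(Br)c3cccnc23)CC1` has phenyl in place of thiophen-2-yl on a saturated chain carbon bound to an amide-type nitrogen. The measured steps at this same place bear on the change. Thiophen-2-yl replacing 3-methoxyphenyl gave a 1.6-fold higher number from compound 1 to compound 3 (0.20 log units; within the scatter). Only the pyridin-2-yl group moved the read-out clearly, with an at least 2.8-fold higher number from compound 1 to compound 2 (0.45 log units; beyond the scatter), and the step of an at least 1.8-fold lower number from compound 2 to compound 3 (0.25 log units; that floor lies within the scatter) rests on the same limit. Compound 4 carries neither a ring nitrogen nor a methoxy group, so it is closest to the pair of compound 1 and compound 3, and no step beyond the scatter is expected in this assay. The estimate means a 1.2-fold lower number from compound 3 to compound 4 (0.09 log units; within the scatter), an expected step of small size. For compound 4 the expected value is 9000 nM, with an estimated range from 4500 nM to 18000 nM.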

Compound 4, half-maximal inhibitory concentration: 8000 nM
The estimate for compound 4 lay 1.1-fold (0.05 log units) above the measured number; low and high end bracket the measured number.
By their numbers in this assay, from the lowest: compounds 1, 4 and 3 (each within the scatter of the next). At a limit, above all of these: compound 2.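

In this assay, phenyl and thiophen-2-yl at this place cannot be told apart (a 1.4-fold lower number from compound 3 to compound 4 (0.14 log units; within the scatter)), and the same holds for phenyl with and without the methoxy group (a 1.1-fold higher number from compound 1 to compound 4 (0.06 log units; within the scatter)). The pyridin-2-yl group now stands clear of a second neighbour, the unsubstituted phenyl (an at least 2.5-fold lower number from compound 2 to compound 4 (0.39 log units; beyond the scatter)), although compound 3 goes against a clean separation, since its step from the same limit has a floor within the scatter (an at least 1.8-fold lower number from compound 2 to compound 3 (0.25 log units; that floor lies within the scatter)). Compound 2 gives a limit and not a number: the limit of > 20000 nM in this assay, at which 1 of the 4 values shown sits.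

From the compounds shown here alone, it remains open whether an amine or a carboxylic acid on the phenyl ring would move the read-out beyond the scatter. The same question stands for a longer chain, such as phenethyl in place of benzyl.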